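A few compounds are considered here, and "the series" means these few. Any claim that something is new, unique, unknown or untested is made for them only; others in the source may bear on it.

Measured compounds:
- Compound 1 `Cc1cc(O)c(C(=O)/C=C/c2ccc(Cl)cc2)c(-c2ccccc2)c1C(=O)/C=C/c1ccc(Cl)cc1` gives 30000 nM
- Compound 2 `Cc1cc(O)c(C(=O)/C=C/c2ccc(F)cc2)c(-c2ccc(Br)cc2)c1C(=O)/C=C/c1ccc(F)cc1` gives "not active" (no number reported)
- Compound 3 `Cc1cc(O)c(C(=O)/C=C/c2ccc(Cl)cc2)c(-c2ccc(Br)cc2)c1C(=O)/C=C/c1ccc(Cl)cc1` gives 32000 nM

The readout throughout is a functional assay on HeLa cells (Homo sapiens) for cytotoxicity, read by MTT assay, with a stated time of 24 h; a lower number here means a stronger inhibitor, a higher number a weaker inhibitor. Compound 3 and compound 1 differ by hydrogen in place of bromo on an aromatic carbon; the step of a 1.1-fold lower number from compound 3 to compound 1 (0.03 log units; within the scatter) shows the change left the number essentially where it was. The difference between the cores of compound 2 and compound 3 is not broken down here. Compound 4 `Cc1cc(O)c(C(=O)/C=C/c2ccc(F)cc2)c(-c2ccccc2)c1C(=O)/C=C/c1ccc(F)cc1` is yet to be measured; it stands to compound 2 as compound 1 stands to compound 3, the same kind of change, (hydrogen in place of bromo on an aromatic carbon). Since compound 2 is reported as "not active" (no number reported) and the matching step from compound 3 to compound 1 was a 1.1-fold lower number from compound 3 to compound 1 (0.03 log units; within the scatter), compound 4 is expected to remain weak, quite possibly with no number reported. The estimate for compound 4 in this assay is 45000 nM, between 20000 nM and 120000 nM.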

Compound 4, half-maximal inhibitory concentration: 30000 nM
The estimate for compound 4 lay 1.5-fold (0.18 log units) above the measured number; low and high end bracket the measured number.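

Compound 2 has no reported number, so the step from compound 2 to compound 4 cannot be read. The compounds shown leave open what the 4-bromophenyl to phenyl change does in the fluoro pair. No supporting data bear on this result.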